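Pyridinyl for chlorophenyl on the piperazine of compound 3

The source may hold more compounds than are shown below. What is called first, only, known or untested is meant among the compounds shown, and "the series" means these compounds.

Measured so far:
Compound 1 `CCC1(CCCCN2CCN(c3ccccc3Cl)CC2)C(=O)Nc2ccccc21` gives 53 nM in an assay on CHO cells for displacement of a labelled ligand from 5-hydroxytryptamine receptor 7 (Homo sapiens), read by scintillation counting; on this read-out higher numbers stand for weaker inhibition and lower numbers for stronger inhibition.
Compound 2 `CCC1(CCCCN2CCN(c3ccc(Cl)cc3)CC2)C(=O)Nc2cc(F)c(Cl)cc21` gives 10 nM in this assay.
Compound 3 `O=C1Nc2cc(F)ccc2C1CCCCN1CCN(c2ccc(Cl)cc2)CC1` gives 25 nM in this assay.

Compound 3 stands second highest of the three numbers. Compound 1 lies nearest, with a higher number beyond the scatter, and compound 2 lies furthest, with a lower number beyond the scatter. Compound 4 `O=C1Nc2cc(F)ccc2C1CCCCN1CCN(c2ccccn2)CC1` differs from compound 3 in one place: pyridin-2-yl in place of 4-chlorophenyl on an amine nitrogen in a ring. For the measured compounds named here, no pair of measured compounds shows this change, so its size is not known from these data. A modest step toward a higher number in this assay is expected, near the edge of the scatter. The step from compound 3 to compound 4 is estimated as a 2.4-fold higher number from compound 3 to compound 4 (0.38 log units; beyond the scatter). Compound 4 is expected to give 60 nM, within 20 nM to 180 nM.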

Compound 4, inhibition constant: 16.8 nM
Compound 4: the middle estimate sits 3.6-fold (0.55 log units) above what was measured; the whole stated range lies above it.
By their numbers in this assay, from the lowest: compounds 2, 4 and 3 (each within the scatter of the next, the first and the last beyond it); then compound 1.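

In this assay the exchange of 4-chlorophenyl for pyridin-2-yl on the ring amine nitrogen gives a 1.5-fold lower number from compound 3 to compound 4 (0.17 log units; within the scatter), so for this pair the chlorine-bearing carbon ring is not required to keep the number in this range. This position on the ring amine nitrogen therefore accepts an aromatic ring with a hetero atom without a change that can be told from the scatter. Nothing available explains this result.

The compounds shown leave open whether phenyl, pyridin-3-yl or pyrimidin-2-yl would read alike on this nitrogen. They also leave open whether pyridin-2-yl would behave the same way on the core of compound 2.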